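Swapping the butylamino group for chloro on the shared core

The source may hold more compounds than are shown below. What is called first, only, known or untested is meant among the compounds shown, and "the series" means these compounds.

Among the compounds with values here, compound 1 `CCCCNc1nc(SCc2ccc([N+](=O)[O-])cc2)c2ncn([C@@H]3O[C@H](CO)[C@@H](O)[C@H]3O)c2n1` gives 325 nM in an assay on K562 cells for displacement of a labelled ligand from Equilibrative nucleoside transporter 1 (Homo sapiens), read by flow cytometry, with a stated time of 45 min (a higher number here means a weaker inhibitor, a lower number a stronger inhibitor), the highest of the two numbers so far; compound 2 `O=[N+]([O-])c1ccc(CSc2nc(NCc3ccccc3)nc3c2ncn3[C@@H]2O[C@H](CO)[C@@H](O)[C@H]2O)cc1` gives 247 nM, and the step of a 1.3-fold lower number from compound 1 to compound 2 (0.12 log units; within the scatter) stays within the scatter. Compound 3 `O=[N+]([O-])c1ccc(CSc2nc(Cl)nc3c2ncn3[C@@H]2O[C@H](CO)[C@@H](O)[C@H]2O)cc1` differs from compound 1 by chloro in place of butylamino on an aromatic carbon. Within the data shown here, the only measured step changed the chain on that nitrogen, not the nitrogen itself, so it bears on this change only loosely. A step of uncertain direction is therefore expected, a 1.5-fold higher number from compound 1 to compound 3 (0.19 log units; within the scatter), and compound 3 is estimated at 500 nM, within 120 nM to 2500 nM.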

Compound 3, inhibition constant: 11 nM
Compound 3: middle estimate off by 45-fold (1.66 log units), on the high side; the whole stated range lies above it.
By their numbers in this assay, from the lowest: compound 3; then compounds 2 and 1 (each within the scatter of the next).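

At this aromatic carbon, the group matters far more than the earlier change to the chain on the nitrogen did: chloro in place of butylamino gives a 30-fold lower number from compound 1 to compound 3 (1.47 log units; beyond the scatter) and chloro in place of benzylamino gives a 22-fold lower number from compound 2 to compound 3 (1.35 log units; beyond the scatter) on the shared core. Both large steps point the same way, so chloro stands apart from both amino groups. Nothing available explains why the number falls so far.

Going by these compounds, it remains open whether the drop follows from chloro itself or from the loss of the amino nitrogen. How bromo or a bare amino group would compare at this carbon is also unknown.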